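Diethylamino for (2-Methoxyethyl)amino: Lipophilicity Outlook

A few compounds are considered here, and "the series" means these few. Any claim that something is new, unique, unknown or untested is made for them only; others in the source may bear on it.

Measured compounds:
Compound 1, `CN1CCN(CCCS(=O)(=O)c2ccc3nc(NC(=O)NC(=O)c4cc(C5CC5)ccc4Cl)sc3c2)CC1` — 2.9
Compound 2, `COCCNCCCS(=O)(=O)c1ccc2nc(NC(=O)NC(=O)c3ccccc3Cl)sc2c1` — 1.3
Compound 3, `CS(=O)(=O)c1ccc2sc(NC(=O)NC(=O)c3ccccc3Cl)nc2c1` — 2.8

In a physicochemical assay for lipophilicity (on this read-out lower numbers stand for lower lipophilicity and higher numbers for higher lipophilicity), compound 2 gives 1.3, the lowest of the three numbers. Its nearest neighbour is compound 3, which in this assay gives 2.8, a gap beyond the scatter; the furthest is compound 1, which gives 2.9, also beyond the scatter. Within the data shown here, none of the three pairs differs in a single place, so no step between measured compounds can be read off.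

Compound 4, `CCN(CC)CCCS(=O)(=O)c1ccc2nc(NC(=O)NC(=O)c3ccccc3Cl)sc2c1`, has not yet been measured. It differs from compound 2 in one place: diethylamino in place of (2-methoxyethyl)amino on a saturated chain carbon, three bonds along the chain from a sulfonyl sulfur. Among the measured compounds shown here, with no measured step of this kind to lean on, the expectation rests on compound 2 alone, whose value of 1.3 sets the starting point. Compound 4 is expected to sit somewhat higher than compound 2 in this assay, a modest upward step of a number 0.50 log units higher from compound 2 to compound 4 (beyond the scatter), larger than the scatter but well short of the distance to compound 3. Compound 4 is therefore estimated at 1.8, with a range from 1.2 to 2.5.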

Compound 4, distribution coefficient: 1.7
Beside the measured number, compound 4's estimate is 0.10 log units above it, within the range that was stated.
By their numbers in this assay, from the lowest: compound 2; then compound 4; then compounds 3 and 1 (each within the scatter of the next).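

In this assay, among these compounds, the change from (2-methoxyethyl)amino to diethylamino on a saturated chain carbon, three bonds along the chain from a sulfonyl sulfur, gives a first reading of this position, with a number 0.40 log units higher from compound 2 to compound 4 (beyond the scatter) as the measured step. The two groups have the same count of heavy atoms, but diethylamino carries a carbon where the other carries an oxygen and has no hydrogen-bond donor, so the step shows that an exchange of this kind at this position can move the number beyond the scatter. No supporting measurement explains the step.

This single pair cannot show which part of the exchange accounts for the step. It also leaves open how a morpholine, a dimethylamino group or a carboxylic acid at the same place would read, and whether the same step would hold on the core of compound 1.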